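Working notes: from compound 3 to compound 4

The source may report more compounds than this note shows. Statements on the series, on what has been measured and on what is new or still open speak of the compounds shown alone.

Measured in an ADME assay on Vero cells (Chlorocebus sabaeus) for cytotoxicity, read by resazurin assay, with a stated time of 72 h; a higher number here means a weaker inhibitor, a lower number a stronger inhibitor:
- compound 1 `O=C(CCN1CCN(c2ccc(F)cc2)CC1)c1ccccc1` gives 13400 nM
- compound 2 `COc1ccc(C(=O)CCN2CCN(c3ccc(F)cc3)CC2)cc1` gives 55000 nM
- compound 3 `O=C(CCN1CCN(c2ccc(F)cc2)CC1)c1ccc(Br)cc1` gives 99500 nM

Compound 3 shares the upper end of these numbers with compound 2, the gap being a 1.8-fold higher number from compound 2 to compound 3 (0.26 log units; within the scatter). Its distance from the hydrogen analogue is larger, at a 7.4-fold higher number from compound 1 to compound 3 (0.87 log units; beyond the scatter).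

The next case is compound 4 `O=C(CCN1CCN(c2ccc(F)cc2)CC1)c1ccc(OC(F)(F)F)cc1`, with trifluoromethoxy in place of bromo on an aromatic carbon. Going by the values given here, no measured compound carries trifluoromethoxy, so the evidence is indirect. Methoxy in place of hydrogen gave a 4.1-fold higher number from compound 1 to compound 2 (0.61 log units; beyond the scatter), a modest step in the same direction as the bromo step. Exchanging methoxy and bromo at this place gave no separable change. On these three compounds alone, the new group is expected to stay near compound 2 and compound 3, with no step beyond the scatter in this assay. The estimated step is a 1.4-fold lower number from compound 3 to compound 4 (0.15 log units; within the scatter). For compound 4 the expected value is 70000 nM, with an estimated range of 28000 nM to 160000 nM.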

Compound 4, half-maximal inhibitory concentration: 70300 nM
Beside the measured number, compound 4's estimate is 1.0-fold (0.00 log units) below it, within the range that was stated.
By their numbers in this assay, from the lowest: compound 1; then compounds 2, 4 and 3 (each within the scatter of the next).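

In this assay, trifluoromethoxy is a third group at this position that separates from hydrogen, with a 5.2-fold higher number from compound 1 to compound 4 (0.72 log units; beyond the scatter), so the change from hydrogen now reads the same way for all three groups. Against its neighbours in the series it does not separate: trifluoromethoxy in place of bromo gives a 1.4-fold lower number from compound 3 to compound 4 (0.15 log units; within the scatter), and trifluoromethyl in place of methyl on the oxygen gives a 1.3-fold higher number from compound 2 to compound 4 (0.11 log units; within the scatter), so neither five heavy atoms for one nor the fluorines on that oxygen substituent yield a readable change here. No supporting measurement is available to account for this grouping.

On these data alone, whether an amine or a carboxylic acid at this position would stay with compound 2, compound 3 and compound 4 or fall nearer compound 1 remains open. Also open, as far as these compounds go, is whether the same grouping would hold with a longer chain in the shared core.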